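The source may report more compounds than this note shows. Statements on the series, on what has been measured and on what is new or still open speak of the compounds shown alone.

Measured compounds and their values in this study:
compound 1 `Cn1cc(-c2ccc(C(F)(F)F)cc2)c2ccc(C(=O)NS(=O)(=O)C3CC3)cc21` — 0.004
compound 2 `CC(C)COc1ccc(-c2cn(C)c3cc(C(=O)NS(C)(=O)=O)c(F)cc23)cn1` — 0.014
compound 3 `Cn1cc(-c2ccc(C(F)(F)F)cc2)c2ccc(C(=O)NS(C)(=O)=O)cc21` — < 0.001

Three compounds were measured in an ADME assay on a cell-free system (plasma, Mus musculus) for protein binding; on this read-out lower numbers stand for a smaller free fraction and higher numbers for a larger free fraction. Compound 1 gives 0.004. Compound 2 gives 0.014 and so stands highest of the two numbers. For compound 3 the assay returns only a limit, < 0.001.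

Compound 3 and compound 1 differ in one place, (cyclopropyl in place of methyl on a sulfonyl sulfur). The step in this assay is an at least 4.0-fold higher number from compound 3 to compound 1 (0.60 log units; beyond the scatter); it is known only as a lower bound because of the limit of < 0.001 in this assay, at which 1 of the 3 values shown sits. The cores of compound 2 and compound 3 differ in more than one place, and that difference is not broken down here.

The unmeasured compound 4 `CC(C)COc1ccc(-c2cn(C)c3cc(C(=O)NS(=O)(=O)C4CC4)c(F)cc23)cn1` carries the same change on the core of compound 2: cyclopropyl in place of methyl on a sulfonyl sulfur. The place reads the same word for word, so the change is the same one. For compound 4 a rise in the unbound fraction is expected, a 2.5-fold higher number from compound 2 to compound 4 (0.40 log units; beyond the scatter). That expectation rests on an at least 4.0-fold higher number from compound 3 to compound 1 (0.60 log units; beyond the scatter), which is only a bound from a single pair, so it is held loosely. Compound 4 is estimated at 0.035, expected to fall between 0.012 and 0.1.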

Compound 4, unbound fraction: 0.006
Compound 4: the middle estimate sits 5.8-fold (0.77 log units) above what was measured; the measured number lies below the stated range.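

In this assay, cyclopropyl in place of methyl on a sulfonyl sulfur gives a 2.3-fold lower number from compound 2 to compound 4 (0.37 log units; beyond the scatter), so on these two cores the same change does not carry over with the same direction: the same change on two cores in this assay, an at least 4.0-fold higher number (0.60 log units; beyond the scatter) from compound 3 to compound 1 and a 2.3-fold lower number (0.37 log units; beyond the scatter) from compound 2 to compound 4, at least 9.3-fold (0.97 log units) apart, beyond the scatter of two such steps. The earlier step is known only as a bound, since compound 3 stands at a limit of the assay: the limit of < 0.001 in this assay, at which 1 of the 4 values shown sits. The two pairs show that the core can matter for this change, but they do not show which of the several differences between the cores is responsible, nor how the change would behave on any third core.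

From the compounds shown here alone, it remains open whether a core carrying only some of those differences would follow compound 1 or compound 4. Going by these compounds, it is equally open whether a longer chain such as propyl, or an amine, on the sulfonyl sulfur would move the unbound fraction the same way on both cores.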